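The compounds below may be only part of what the source reports. "The series", "measured", "known", "first", "only" and "open" are said of these compounds alone.

Compound 1 `COc1cc(CNC(=O)/C=C/c2ccccc2)ccc1O` gives 3660 nM in a functional assay on SH-SY5Y cells (Homo sapiens) for cytotoxicity, read by MTT assay, with stated times of 24 h and 4 h; a higher number here means that more compound is needed for the effect, a lower number that less compound is needed. Compound 2 `COc1cc(CNC(=O)/C=C/c2ccccc2O)ccc1O` gives 9760 nM in this assay. Compound 3 `COc1cc(CNC(=O)/C=C/c2cccc(OCc3nc(C)c(C)nc3C)c2)ccc1O` gives 8090 nM in this assay.

Among these three, compound 3 has the second highest number; its value lies within the scatter of compound 2 and beyond the scatter of compound 1. Compound 4 `COc1cc(CNC(=O)/C=C/c2cccc(OCc3nc(C)c(C)nc3C)c2)ccc1OCc1nc(C)c(C)nc1C` differs from compound 3 by (3,5,6-trimethylpyrazin-2-yl)methyl in place of hydrogen on an oxygen on an aromatic ring. Within the data shown here, the only measured single step, a 2.7-fold higher number from compound 1 to compound 2 (0.43 log units; beyond the scatter), concerns a hydroxy added to an aromatic carbon and does not match this change; no measured step covers replacing the hydrogen of a hydroxy with a larger group. With little to go on, compound 4 is expected to move by a 1.1-fold lower number from compound 3 to compound 4 (0.03 log units; within the scatter), that is, no step beyond the scatter. The estimate for compound 4 in this assay is 7500 nM, with a range from 3000 nM to 20000 nM.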

Compound 4, half-maximal effective concentration: 8700 nM
Estimate against measurement, compound 4: 1.2-fold (0.06 log units) below, within the range that was stated.
By their numbers in this assay, from the lowest: compound 1; then compounds 3, 4 and 2 (each within the scatter of the next).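

In this assay, (3,5,6-trimethylpyrazin-2-yl)methyl in place of hydrogen on this oxygen gives a 1.1-fold higher number from compound 3 to compound 4 (0.03 log units; within the scatter). Among these compounds, the earlier compounds all carried a free hydroxy here, so this is the first sign that, in this pair, the number does not depend on that hydrogen and that this position accepts a group with an aromatic ring. Nothing shown explains this result. From the compounds shown here alone, whether a small ethyl group or a chain ending in a carboxylic acid on this oxygen would behave the same stays open.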